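From 4-hydroxy-3-methoxyphenyl to 3-aminophenyl

The compounds below may be only part of what the source reports. "The series", "measured", "known", "first", "only" and "open" are said of these compounds alone.

In a functional assay on A549 cells (Homo sapiens) for antiproliferative activity, read by MTT assay, with a stated time of 48 h (a lower number here means a stronger inhibitor, a higher number a weaker inhibitor), compound 1 `COc1cc(-c2cccc3nc(-c4cccc(Br)c4)oc23)cc(OC)c1OC`, carrying 3-bromophenyl, gives 2100 nM. Compound 2 `COc1cc(-c2cccc3nc(-c4ccc(Br)cc4)oc23)cc(OC)c1OC`, carrying 4-bromophenyl, gives > 25000 nM, which is a limit of the assay and not a number. Compound 3 `COc1cc(-c2nc3cccc(-c4cc(OC)c(OC)c(OC)c4)c3o2)ccc1O`, carrying 4-hydroxy-3-methoxyphenyl, gives 15700 nM, the higher of the two actual numbers. Compound 4 `COc1cc(-c2cccc3nc(-c4cccc(N)c4)oc23)cc(OC)c1OC` keeps the shared core but has 3-aminophenyl in place of 4-hydroxy-3-methoxyphenyl on an aromatic carbon. Going by the values given here, two measured steps bear on this change. Exchanging the bromophenyl groups gave an at least 11-fold higher number from compound 1 to compound 2 (1.07 log units; beyond the scatter), a large step, and replacing 3-bromophenyl with the group that now leaves gave a 7.5-fold higher number from compound 1 to compound 3 (0.87 log units; beyond the scatter), a modest one. The name 3-aminophenyl is closer to 3-bromophenyl, so a partial return toward compound 1 and its 2100 nM seems likely, although no amino group has been tested here. The expected result is a modest move to a lower number, a 2.9-fold lower number from compound 3 to compound 4 (0.46 log units; beyond the scatter). For compound 4 the estimated value is 5500 nM, with an expected range from 1500 nM to 20000 nM.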

Compound 4, half-maximal inhibitory concentration: 4700 nM
The estimate for compound 4 lay 1.2-fold (0.07 log units) above the measured number, within the range that was stated.
By their numbers in this assay, from the lowest: compound 1; then compound 4; then compound 3. At a limit, above all of these: compound 2.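

In this assay, the 3-aminophenyl group shows that bromo is not the only substituent on this ring that keeps activity, with a 3.3-fold lower number from compound 3 to compound 4 (0.52 log units; beyond the scatter), a modest gain over 4-hydroxy-3-methoxyphenyl. Bromo still holds an edge, with a 2.2-fold higher number from compound 1 to compound 4 (0.35 log units; beyond the scatter), so amino in its place recovers only part of the activity lost in compound 3. Compound 2 stands at a limit of the assay and not a number, so the reading of an at least 5.3-fold lower number from compound 2 to compound 4 (0.72 log units; beyond the scatter) is only a floor, on this basis: the limit of > 25000 nM in this assay, at which 1 of the 4 values shown sits.

Going by these compounds, how a methoxy group or a carboxylic acid would fare in place of the amino group stays open. Also open, on these data alone, is whether any group on this ring can give a lower number than bromo does.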